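Swapping the Ester Arm for a Dimethylaminoethyl Chain

A few compounds are considered here, and "the series" means these few. Any claim that something is new, unique, unknown or untested is made for them only; others in the source may bear on it.

Three compounds share one core and differ only in the chain carried on the aromatic nitrogen. Compound 1 `CCn1c(=O)n(C2OC(CO)[C@@H](O)[C@H]2O)c2nc(N)nc(O)c21` gives 82% in a functional assay on the whole organism with Mus musculus as the target; a lower number here means a smaller maximal response, a higher number a larger maximal response. Compound 2 `CCCCCCCCCCn1c(=O)n(C2OC(CO)[C@@H](O)[C@H]2O)c2nc(N)nc(O)c21` gives 0% in this assay, and compound 3 `CCOC(=O)Cn1c(=O)n(C2OC(CO)[C@@H](O)[C@H]2O)c2nc(N)nc(O)c21` gives 58% in this assay. Compound 3 thus stands second highest of the three: the step of a number 24 percentage points lower from compound 1 to compound 3 (beyond the scatter) is modest, whereas the step of a number 58 percentage points higher from compound 2 to compound 3 (beyond the scatter) is large, as is the step of a number 82 percentage points lower from compound 1 to compound 2 (beyond the scatter).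

Compound 4 `CN(C)CCCn1c(=O)n(C2OC(CO)[C@@H](O)[C@H]2O)c2nc(N)nc(O)c21` has not yet been measured. It differs from compound 3 in one place: 2-(dimethylamino)ethyl in place of ethoxycarbonyl on a saturated chain carbon bound to an aromatic nitrogen

The two measured steps that reach compound 3 bear on this change, since both alter the same carbon bound to the aromatic nitrogen. They show that a long nonyl chain abolishes the response, while a short ethyl or a five-heavy-atom ester arm retains much of it. The entering group matches the leaving group in count of heavy atoms and is far shorter than the chain of compound 2, so the response of compound 4 is expected to stay near that of compound 3, with the step of a number 2 percentage points higher from compound 3 to compound 4 (within the scatter) expected to lie within the scatter. Compound 4 is estimated at 60%, in a range from 30% to 85%.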

Compound 4, largest response reached (reported as maximal response), in percent of the reference or control that the assay uses: 63%
Compound 4: middle estimate off by 3 percentage points, on the low side; the measured number falls inside the stated range.
By their numbers in this assay, from the lowest: compound 2; then compounds 3 and 4 (each within the scatter of the next); then compound 1.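

In this assay, a number 5 percentage points higher from compound 3 to compound 4 (within the scatter) shows that the ester carbonyl is not needed at this place to keep the response: 2-(dimethylamino)ethyl, with 5 heavy atoms including a nitrogen, reads the same as ethoxycarbonyl, which also has 5 heavy atoms but includes two oxygens. The other two steps place this amine arm as the ester arm was placed: a number 63 percentage points higher from compound 2 to compound 4 (beyond the scatter) shows that a chain end carrying dimethylamino keeps a response that the long all-carbon chain loses entirely, while a number 19 percentage points lower from compound 1 to compound 4 (beyond the scatter) shows that the arm still falls short of the small ethyl group. No measurement offered here explains why these two different arms read alike.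

The compounds shown leave open how much of the response depends on chain length and how much on what the chain carries, since a butyl or hexyl chain would separate the two effects. They also leave open how a free carboxylic acid, a primary amine or a morpholine at the chain end would compare with the ester and dimethylamino arms.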